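A Hexyl Extension on a Macrolide Amide Side Chain

The compounds below may be only part of what the source reports. "The series", "measured", "known", "first", "only" and "open" are said of these compounds alone.

Compound 1 `CC[C@H]1OC(=O)[C@H](C)[C@@H](O[C@H]2C[C@@](C)(OC)[C@@H](OCCCNC(C)=O)[C@H](C)O2)[C@H](C)[C@@H](O[C@@H]2O[C@H](C)C[C@H](N(C)C)[C@H]2O)[C@](C)(O)C[C@@H](C)CN(C)[C@H](C)[C@@H](O)[C@]1(C)O` and compound 3 `CC[C@H]1OC(=O)[C@H](C)[C@@H](O[C@H]2C[C@@](C)(OC)[C@@H](O)[C@H](C)O2)[C@H](C)[C@@H](O[C@@H]2O[C@H](C)C[C@H](N(C)C)[C@H]2O)[C@](C)(OC)C[C@@H](C)C(=O)[C@H](C)[C@@H](OCCCNC(C)=O)[C@]1(C)O` share the broad shape of a large macrolide, yet the difference between their two cores is not broken down here. In a physicochemical assay for lipophilicity, read by HPLC, measured as chromatographic lipophilicity, at pH 7.4 (a lower number here means a more polar compound, a higher number a more lipophilic compound), compound 1 gives 2.06, and compound 3 gives 2.72, so compound 3 sits second highest of the three measured numbers, beyond the scatter from compound 1.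

Compound 2 `CCCCCCCC(=O)NCCCO[C@H]1[C@H](C)O[C@@H](O[C@H]2[C@H](C)[C@@H](O[C@@H]3O[C@H](C)C[C@H](N(C)C)[C@H]3O)[C@](C)(O)C[C@@H](C)CN(C)[C@H](C)[C@@H](O)[C@](C)(O)[C@@H](CC)OC(=O)[C@@H]2C)C[C@@]1(C)OC` is compound 1 with one change: hexyl in place of hydrogen on a saturated chain carbon bound to a carbonyl carbon. In this assay compound 2 gives 4.1. That single change moved the reading by a number 2.04 log units higher from compound 1 to compound 2 (beyond the scatter), a large step in the direction of a more lipophilic compound, which is the expected direction for adding a chain of six carbons.

Compound 4 `CCCCCCCC(=O)NCCCO[C@@H]1[C@@H](C)C(=O)[C@H](C)C[C@@](C)(OC)[C@H](O[C@@H]2O[C@H](C)C[C@H](N(C)C)[C@H]2O)[C@@H](C)[C@H](O[C@H]2C[C@@](C)(OC)[C@@H](O)[C@H](C)O2)[C@@H](C)C(=O)O[C@H](CC)[C@@]1(C)O` is the still unmeasured partner of compound 3, carrying the same change: hexyl in place of hydrogen on a saturated chain carbon bound to a carbonyl carbon. The two place descriptions match word for word, so this is the same change made on the other core.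

For the measured compounds named here, for compound 4 the step is expected to be a number 1.98 log units higher from compound 3 to compound 4 (beyond the scatter), close to the step from compound 1 to compound 2, because a number 2.04 log units higher from compound 1 to compound 2 (beyond the scatter) is the only measured example of this change and nothing here suggests the core of compound 3 would answer differently. Compound 4 is therefore estimated at 4.7, with the likely range running from 4.2 to 5.2.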

Compound 4, distribution coefficient: 5.07
Beside the measured number, compound 4's estimate is 0.37 log units below it, within the range that was stated.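

In this assay, the same change, hexyl in place of hydrogen on a saturated chain carbon bound to a carbonyl carbon, gives a number 2.35 log units higher from compound 3 to compound 4 (beyond the scatter) on one core and a number 2.04 log units higher from compound 1 to compound 2 (beyond the scatter) on the other. Both steps are large and point the same way, so in these two pairs the change carried over from one core to the other in direction and in broad size. Two pairs cannot show that it would carry over as well to any further core, and nothing measured here bears on why the two steps came out as they did.

The compounds shown leave open how the reading would respond to other groups at this place, such as a butyl chain, a longer decyl chain, or a hexyl chain ending in an amine or a carboxylic acid instead of a plain carbon chain. For the compounds shown here, they also leave open whether the reading rises steadily with chain length on either core, and whether the change would carry over in other kinds of assay, since only this single physicochemical reading is available for these pairs.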